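The source may hold more compounds than are shown below. What is called first, only, known or untested is meant among the compounds shown, and "the series" means these compounds.

In a functional assay on UACC-62 cells (Homo sapiens) for inhibition, read by sulforhodamine B assay, with a stated time of 48 h (a higher number here means a weaker inhibitor of growth, a lower number a stronger inhibitor of growth), compound 1 `COc1ccc(/C=C/C2(C)C=CC(=O)O2)cc1OC` gives 84100 nM and compound 2 `CC1(/C=C/c2cccc(O)c2)C=CC(=O)O1` gives 108000 nM, so these two values lie within the usual scatter of each other. Compound 3 `COc1cccc(/C=C/C2(C)C=CC(=O)O2)c1` has not yet been measured. It differs from compound 2 by a single change, methyl in place of hydrogen on an oxygen on an aromatic ring, which turns hydroxy to methoxy. Within the data shown here, no measured pair shows this change on its own, so no shift beyond the scatter is expected in this assay. The estimated step, a 1.2-fold lower number from compound 2 to compound 3 (0.08 log units; within the scatter), is correspondingly small. Compound 3 is expected at 90000 nM, with an estimated range from 40000 nM to 200000 nM.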

Compound 3, concentration for total growth inhibition: 55800 nM
For compound 3 the middle estimate is 1.6-fold (0.21 log units) above the measured one, and the stated range covers the measured number.
By their numbers in this assay, from the lowest: compounds 3, 1 and 2 (each within the scatter of the next).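

In this assay, capping the oxygen on the aromatic ring, hydroxy to methoxy, gives a step that stays within the scatter (a 1.9-fold lower number from compound 2 to compound 3 (0.29 log units; within the scatter)). So at this place, a hydrogen or a methyl on the oxygen makes no clear difference. Hydrogen in place of methoxy on an aromatic carbon is also within the scatter (a 1.5-fold lower number from compound 1 to compound 3 (0.18 log units; within the scatter)), so the second methoxy of compound 1 makes no clear difference either. Nothing here gives a cause for these small steps.

The compounds shown leave open whether a longer chain on this oxygen, such as propyl, would move the number beyond the scatter. The same question stands for an amine or a carboxylic acid on the aromatic ring.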